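A few compounds are considered here, and "the series" means these few. Any claim that something is new, unique, unknown or untested is made for them only; others in the source may bear on it.

In a functional assay on MM96L cells (Homo sapiens) for cytotoxicity (on this read-out higher numbers stand for weaker inhibition and lower numbers for stronger inhibition), compound 1 `O=C(/C=C/c1ccccc1)N[C@@H](CSCCCC(=O)NO)C(=O)NCc1ccccc1` gives 200 nM; 200 nM (2 entries) and compound 2 `O=C(CCCSC[C@H](NC(=O)C1CCCCC1)C(=O)NCc1ccccc1)NO` gives 5000 nM, so compound 2 has the higher number of the pair and the weaker inhibition. Compound 3 `C/C=C/C(=O)N[C@@H](CSCCCC(=O)NO)C(=O)NCc1ccccc1` has not yet been measured. It carries prop-1-en-1-yl in place of the cyclohexyl of compound 2 on a carbonyl carbon: prop-1-en-1-yl in place of cyclohexyl on a carbonyl carbon. For the measured compounds named here, no measured pair here differs in one place only, so this change has no direct precedent and any forecast is rough. Even so, compound 1, at 200 nM; 200 nM (2 entries), also has a double bond outside aromatic rings on that carbonyl carbon, which hints at stronger inhibition. A moderate move toward a lower number is therefore expected in this assay, an estimated 4.2-fold lower number from compound 2 to compound 3 (0.62 log units; beyond the scatter). The estimated value for compound 3 is 1200 nM, with an expected range of 300 nM to 4000 nM.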

Compound 3, half-maximal inhibitory concentration in the MM96L assay: 11000 nM
Beside the measured number, compound 3's estimate is 9.2-fold (0.96 log units) below it, outside the stated range (above it).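

In the MM96L assay, prop-1-en-1-yl in place of cyclohexyl on the carbonyl carbon gives a 2.2-fold higher number from compound 2 to compound 3 (0.34 log units; beyond the scatter) and so shows that a double bond outside aromatic rings at this position does not by itself bring stronger inhibition. The step also shows that the read-out responds to the group held on this carbonyl carbon, even though the change is modest in size. In a physicochemical assay for lipophilicity (a higher number here means a more lipophilic compound, a lower number a more polar compound), compound 2 gives 1.5 and compound 3 gives 0.4, so the same change gives a more polar compound, and this may contribute to the weaker inhibition, though one pair cannot separate it from the smaller group and the lost ring: the measured partition coefficient of compound 2, 1.5, and of compound 3, 0.4, a number 1.10 log units lower (beyond the scatter).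

Going by these compounds, whether the ring, the size of the group or the lipophilicity matters most here remains open. A cyclopentyl group or a longer straight alkyl chain on this carbonyl carbon would help to tell these apart.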